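The compounds below may be only part of what the source reports. "The series", "measured", "known", "first", "only" and "open" are said of these compounds alone.

Among the measured compounds shown here, in a functional assay on H4 cells for agonist activity at growth hormone secretagogue receptor type 1 (Homo sapiens), read by FLIPR (a higher number here means that more compound is needed for the effect, a lower number that less compound is needed), compound 2 `CC(C)(N)C(=O)N[C@H](COCc1ccccc1)c1nnn(Cc2cccc(NS(C)(=O)=O)c2)n1` gives 868 nM, the highest of the two numbers measured so far. Its nearest neighbour on the scale is compound 1 `CC(C)(N)C(=O)N[C@H](COCc1ccccc1)c1nnnn1CCC#N`, which in this assay gives 30 nM, a gap that lies well beyond the scatter of repeated measurements.

Compound 3 `CC(C)(N)C(=O)N[C@H](COCc1ccccc1)c1nnn(CCCCC#N)n1` has not yet been measured. It differs from compound 2 in one place: 3-cyanopropyl in place of 3-(methanesulfonamido)phenyl on a saturated chain carbon bound to an aromatic nitrogen. The large group with its ring and its hydrogen-bond donor is thus removed, and a short chain ending in a nitrile takes its place on the shared core. For the measured compounds named here, no step between two measured compounds matches this change exactly, so the expectation rests on the two values at hand.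

For compound 3 the number in this assay is expected to move downward from compound 2 by an 8.7-fold lower number from compound 2 to compound 3 (0.94 log units; beyond the scatter), because the smaller compound 1 gives 30 nM in this assay. Compound 3 is therefore estimated at 100 nM, with a range from 30 nM to 400 nM.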

Compound 3, half-maximal effective concentration: 1860 nM
Beside the measured number, compound 3's estimate is 19-fold (1.27 log units) below it; measured number outside the range, above it.
By their numbers in this assay, from the lowest: compound 1; then compound 2; then compound 3.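

In this assay, swapping 3-(methanesulfonamido)phenyl for 3-cyanopropyl on the saturated chain carbon bound to an aromatic nitrogen gives a 2.1-fold higher number from compound 2 to compound 3 (0.33 log units; beyond the scatter), so the change is modest but runs upward. Shedding the aromatic ring and the hydrogen-bond donor of this group therefore does not bring the number down, and the shorter nitrile-ending group needs somewhat more compound for the effect. Nothing measured on either group accounts for this step.

As far as these compounds go, the ring and the methanesulfonamido part leave together in this change, so their separate contributions remain open; a plain benzyl group at this position would pull them apart. Among the compounds shown here, it also remains open how a chain of this kind would behave with an amine or a carboxylic acid at its end in place of the nitrile, and no single-change step yet connects compound 1 to compound 2 or compound 3.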